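Swapping methylsulfanyl for methylamino on a dihydropyrimidine core

The source may report more compounds than this note shows. Statements on the series, on what has been measured and on what is new or still open speak of the compounds shown alone.

Compound 1 `COC(=O)C1=C(C)N=C(SC)NC1c1cccc([N+](=O)[O-])c1` and compound 2 `COC(=O)C1=C(C)N=C(SC)N(C(=O)OC(C)C)C1c1cccc([N+](=O)[O-])c1` share the same core and differ only at one ring nitrogen. In an assay on HEK293 cells for antagonist activity at Voltage-dependent L-type calcium channel subunit alpha-1D (Rattus norvegicus), read by FLIPR (on this read-out lower numbers stand for stronger inhibition and higher numbers for weaker inhibition), compound 1 gives 10600 nM, and compound 2 gives 5580 nM. For the measured compounds named here, the step of a 1.9-fold lower number from compound 1 to compound 2 (0.28 log units; within the scatter) is the only comparison at hand, and it leaves the two values within the scatter of each other, so neither can be called stronger. Compound 3 `CNC1=NC(C)=C(C(=O)OC)C(c2cccc([N+](=O)[O-])c2)N1C(=O)OC(C)C` keeps the isopropoxycarbonyl group of compound 2 and changes a different place: methylamino in place of methylsulfanyl on a carbon with a double bond to nitrogen. Going by the values given here, no measured step touches this position, so the one comparison available, between compound 1 and compound 2, does not bear on it. Without a precedent for this swap, the expectation is a change no larger than the scatter, that is a 1.1-fold higher number from compound 2 to compound 3 (0.03 log units; within the scatter). Compound 3 is therefore estimated at 6000 nM, with a range from 1500 nM to 25000 nM.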

Compound 3, half-maximal inhibitory concentration: 4220 nM
Compound 3: the middle estimate sits 1.4-fold (0.15 log units) above what was measured; the range from low to high includes it.
By their numbers in this assay, from the lowest: compounds 3, 2 and 1 (each within the scatter of the next, the first and the last beyond it).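

In this assay the swap at this position is a 1.3-fold lower number from compound 2 to compound 3 (0.12 log units; within the scatter) and so gives no sign of a difference between the two compounds. For the compounds shown here, this is the first look at the carbon with a double bond to nitrogen, and it shows that methylsulfanyl can give way to methylamino there, with a hydrogen-bond donor entering where there was none, without a change that can be told from the scatter. No outside measurement is at hand to explain this result.

As far as these compounds go, it remains open whether a free amine, dimethylamino or a longer chain such as butylamino at this carbon would also stay within the scatter. Also open, from the compounds shown here alone, is whether methylamino would behave the same way with hydrogen in place of the isopropoxycarbonyl group on the ring nitrogen.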